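Moving one bromine on the thiophene of compound 3

This account rests on a few compounds, and the source may have more. Where it says the series, first, only, none or still open, it means among the compounds named here.

Measured in a functional assay on HUVEC cells (Homo sapiens), read by BrdU incorporation, with a stated time of 72 h (on this read-out lower numbers stand for stronger inhibition and higher numbers for weaker inhibition), so far
- compound 1 `Cc1ccc2nc(Cl)c(/C=C/C(=O)c3sccc3C)cc2c1` gives 127 nM
- compound 2 `Cc1ccc2nc(Cl)c(/C=C/C(=O)c3cc(Cl)sc3Cl)cc2c1` gives 26.2 nM
- compound 3 `Cc1ccc2nc(Cl)c(/C=C/C(=O)c3ccc(Br)s3)cc2c1` gives 88.4 nM

Compound 3 stands close to compound 1, with a 1.4-fold lower number from compound 1 to compound 3 (0.16 log units; within the scatter) between them. It stands apart from compound 2, with a 3.4-fold higher number from compound 2 to compound 3 (0.53 log units; beyond the scatter) as the gap.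

The next structure is compound 4 `Cc1ccc2nc(Cl)c(/C=C/C(=O)c3sccc3Br)cc2c1` with 3-bromothiophen-2-yl in place of 5-bromothiophen-2-yl on a carbonyl carbon and nothing else altered. Going by the values given here, no measured pair moves a bromine alone, so the evidence is indirect.

Compound 1 carries 3-methylthiophen-2-yl, the measured group whose name comes nearest to the entering one. Its exchange for the group of compound 3 was a 1.4-fold lower number from compound 1 to compound 3 (0.16 log units; within the scatter) and so made no real difference. The larger 4.8-fold lower number from compound 1 to compound 2 (0.69 log units; beyond the scatter) came with 2,5-dichlorothiophen-3-yl, a group that compound 4 does not carry, so it says less here.

In this assay no change beyond the scatter is therefore expected, and the estimated step is a 1.2-fold higher number from compound 3 to compound 4 (0.07 log units; within the scatter) at most a small one. For compound 4 the estimated value is 105 nM with an expected range from 45 nM to 240 nM in this read-out.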

Compound 4, half-maximal inhibitory concentration: 61.9 nM
Compound 4: the middle estimate sits 1.7-fold (0.23 log units) above what was measured, and the stated range covers the measured number.
By their numbers in this assay, from the lowest: compound 2; then compounds 4, 3 and 1 (each within the scatter of the next, the first and the last beyond it).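

In this assay, moving the bromine gives a 1.4-fold lower number from compound 3 to compound 4 (0.15 log units; within the scatter) and leaves the atoms unchanged, so on this read-out 3-bromothiophen-2-yl and 5-bromothiophen-2-yl on a carbonyl carbon cannot be told apart. The new pair that changes a single substituent is more informative: bromo in place of methyl on an aromatic carbon gives a 2.1-fold lower number from compound 1 to compound 4 (0.31 log units; beyond the scatter) and so produces a real but modest change, although moving the bromine did not. The 2,5-dichlorothiophen-3-yl group still holds the lowest number of the set, with a 2.4-fold higher number from compound 2 to compound 4 (0.37 log units; beyond the scatter) as the modest gap, and nothing measured here explains any of these differences.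

Still open, from the compounds shown here alone, is whether the gain from bromo over methyl extends to other groups on the same aromatic carbon, such as an amine, a methoxy group or a carboxylic acid. Also open, going by these compounds, is whether adding a chlorine to 3-bromothiophen-2-yl, or replacing the thiophene with a plain phenyl ring, would bring the number closer to that of compound 2 or carry it further away.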